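The compounds below may be only part of what the source reports. "The series", "measured", "known", "first", "only" and "open" are said of these compounds alone.

Measured compounds:
compound 1, `Cc1ccc2[nH]c(-c3c(-c4ccc(F)cc4)nc4sc(C)nn34)nc2c1`, in a functional assay on DU-145 cells (Homo sapiens) for antiproliferative activity, read by MTT assay (on this read-out higher numbers stand for weaker inhibition and lower numbers for stronger inhibition), gives 19900 nM
compound 2, `Cc1ccc(-c2nc3sc(C)nn3c2-c2nc3cc(C)ccc3[nH]2)cc1`, in this assay gives 10700 nM
compound 3, `Cc1ccc(-c2nc3sc(C)nn3c2-c2nc3c(C)c(C)ccc3[nH]2)cc1`, in this assay gives 12500 nM

Compound 1 holds the highest of the three numbers, but its distance to both others stays within the scatter, so no order among the three is claimed. The step from compound 1 to compound 2 is fluoro in place of methyl on an aromatic carbon read in reverse, and it gives a 1.9-fold lower number from compound 1 to compound 2 (0.27 log units; within the scatter). The step from compound 2 to compound 3 is methyl in place of hydrogen on an aromatic carbon, and it gives a 1.2-fold higher number from compound 2 to compound 3 (0.07 log units; within the scatter).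

Compound 4, `Cc1nn2c(-c3nc4cc(C)c(C)cc4[nH]3)c(-c3ccc(F)cc3)nc2s1`, is not yet measured. It differs from compound 1 by methyl in place of hydrogen on an aromatic carbon. Among the compounds with values here, this is the same kind of change as the one from compound 2 to compound 3, but not the same: in compound 3 the entering methyl sits ortho to a fused ring, ortho to a methyl group and meta to a fused ring, whereas in compound 4 it sits ortho to a methyl group, meta to a fused ring and para to a fused ring. The cores of compound 1 and compound 2 differ by fluoro in place of methyl on an aromatic carbon, fluoro in place of methyl, with the rest shared.

Within the data shown here, for this assay the expected step from compound 1 to compound 4 is a 1.1-fold higher number from compound 1 to compound 4 (0.04 log units; within the scatter), close to the earlier 1.2-fold higher number from compound 2 to compound 3 (0.07 log units; within the scatter), resting on the one measured pair, compound 2 and compound 3. Compound 4 is therefore estimated at 22000 nM, expected between 11000 nM and 45000 nM.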

Compound 4, half-maximal inhibitory concentration: > 30000 nM
Compound 4 was reported as a limit; the forecaster's own chance of this, stated with the estimate: 10%; middle value at least 1.3-fold (0.13 log units) away from the limit.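

Compound 4 gives > 30000 nM in this assay, which is a limit of the assay and not a number: the limit of > 30000 nM in this assay, at which 1 of the 4 values shown sits.

Methyl in place of hydrogen on an aromatic carbon gives an at least 1.5-fold higher number from compound 1 to compound 4 (0.17 log units; that floor lies within the scatter), and that figure is only a floor for the change on the core of compound 1. The two cores are not shown to respond differently, and the change is not shown to carry over unaltered either, the more so as the entering methyl in compound 4 sits ortho to a methyl group, meta to a fused ring and para to a fused ring, which is not the place it takes in compound 3: the same change on two cores in this assay, a 1.2-fold higher number (0.07 log units; within the scatter) from compound 2 to compound 3 and an at least 1.5-fold higher number (0.17 log units; that floor lies within the scatter) from compound 1 to compound 4; the limit leaves it open whether they differ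

The compounds shown vary only fluoro, methyl and hydrogen, so it stays open how an amine, a carboxylic acid or a longer chain at either varied place would read in this assay. Also open, as far as these compounds go, is whether a methyl in the place it takes in compound 3 would, on the core of compound 1, give a step like the one on the core of compound 2.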